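Amide to benzylamine on the shared core

This account rests on a few compounds, and the source may have more. Where it says the series, first, only, none or still open, it means among the compounds named here.

Compound 2 `CC(C)c1onc(-c2c(Cl)cccc2Cl)c1COc1ccc(NC(=O)c2ccc(C(=O)O)cc2)c(C(F)(F)F)n1` gives the higher of the two efficacies in an assay on isolated protein for agonist activity at Bile acid receptor (Homo sapiens), read by FRET (on this read-out higher numbers stand for larger maximal responses and lower numbers for smaller maximal responses), with a reading of 109%. Compound 1 `CC(C)c1onc(-c2c(Cl)cccc2Cl)c1COc1ccc(N(C)C(=O)c2ccc(C(=O)O)cc2)c(C(F)(F)F)n1` differs only by a methyl on the amide-type nitrogen and in this assay gives 101%; the step of a number 8 percentage points higher from compound 1 to compound 2 (within the scatter) lies within the scatter. Compound 3 `CC(C)c1onc(-c2c(Cl)cccc2Cl)c1COc1ccc(NCc2ccc(C(=O)O)cc2)c(C(F)(F)F)n1` carries the change (4-carboxybenzyl in place of (4-carboxyphenyl)carbonyl on a nitrogen on an aromatic ring). For the measured compounds named here, no measured step removes the carbonyl, so the one known step offers little guidance; the change is larger than that from compound 1 to compound 2. The efficacy of compound 3 is expected to stay close to that of compound 2, a step of a number 19 percentage points lower from compound 2 to compound 3 (beyond the scatter), with a wide range. Compound 3 is estimated at 90%, between 50% and 120%.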

Compound 3, largest response reached (reported as efficacy), in percent of the reference or control that the assay uses: 97%
For compound 3 the middle estimate is 7 percentage points below the measured one; the range from low to high includes it.
By their numbers in this assay, from the lowest: compounds 3, 1 and 2 (each within the scatter of the next, the first and the last beyond it).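

In this assay, removing the carbonyl from this substituent on the nitrogen has a measurable cost, which the methyl change did not show: 4-carboxybenzyl in place of (4-carboxyphenyl)carbonyl gives a number 12 percentage points lower from compound 2 to compound 3 (beyond the scatter). The carbonyl is still not needed for a high maximal response, since compound 3 reaches 97%. No available evidence bears on this step.

The compounds shown leave open how a methyl on the nitrogen of compound 3 would affect the response. They also leave open whether a tetrazole could replace the carboxylic acid.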